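Bromo-to-chloro swap on the fused ring of compound 3

This account rests on a few compounds, and the source may have more. Where it says the series, first, only, none or still open, it means among the compounds named here.

Three compounds in this series carry numbers in a functional assay on cells (Melanoma cell, Homo sapiens) for cytotoxicity, read by sulforhodamine B assay, with a stated time of 48 h; on this read-out lower numbers stand for stronger inhibition of growth and higher numbers for weaker inhibition of growth. Compound 1 `O=C1N=C(N2N=C(c3ccccc3)CC2c2ccc(Cl)cc2)S/C1=C1/C(=O)Nc2ccccc21` gives 280 nM, and compound 2 `CN(C)c1ccc(C2CC(c3ccccc3)=NN2C2=NC(=O)/C(=C3\C(=O)Nc4ccc(Cl)cc43)S2)cc1` gives 260 nM. Compound 3 `COc1ccc(-c2cc(-c3ccc(Cl)cc3)n(C3C(=O)Nc4ccc(Br)cc43)n2)cc1` gives 13200 nM, the highest of the three numbers, with its gaps to compound 1 and to compound 2 both beyond the scatter. Compound 4 `COc1ccc(-c2cc(-c3ccc(Cl)cc3)n(C3C(=O)Nc4ccc(Cl)cc43)n2)cc1` is not yet measured; it differs from compound 3 by chloro in place of bromo on an aromatic carbon. Among the compounds with values here, no measured pair shows such a swap, so the size of the step rests on the change alone. Compound 4 is expected to give 13000 nM in this assay, with a range of 5500 nM to 31000 nM. The expected step of a 1.0-fold lower number from compound 3 to compound 4 (0.01 log units; within the scatter) is estimated to stay within the scatter, in no clear direction.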

Compound 4, concentration for 50% growth inhibition: 9400 nM
For compound 4 the middle estimate is 1.4-fold (0.14 log units) above the measured one, within the range that was stated.
By their numbers in this assay, from the lowest: compounds 2 and 1 (each within the scatter of the next); then compounds 4 and 3 (each within the scatter of the next).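

In this assay, within the data shown here, the only pair differing in one place gives a 1.4-fold lower number from compound 3 to compound 4 (0.15 log units; within the scatter), so on this read-out chloro and bromo at this aromatic carbon of the fused system cannot be told apart. Among these compounds, this is the first direct reading at this position, and it shows that this exchange of one halogen for the other does not move the number beyond the scatter. No measured data bear on why the two halogens read alike.

Still open, on these data alone, is whether an amine or a carboxylic acid at this carbon would shift the number beyond the scatter. As far as these compounds go, whether a bare hydrogen there would do so is equally open.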